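A few compounds are considered here, and "the series" means these few. Any claim that something is new, unique, unknown or untested is made for them only; others in the source may bear on it.

In a functional assay on HT-29 cells (Homo sapiens) for inhibition (on this read-out lower numbers stand for stronger inhibition and higher numbers for weaker inhibition), compound 1 `CN(C)c1ccc(/C=C/c2ccc3ccccc3c2)cc1` gives 3660 nM and compound 2 `C(=C\c1cccc2ccccc12)\c1ccc2ccccc2c1` gives 3570 nM with the two values within the usual scatter of each other. Compound 3 `COc1cc(/C=C/c2ccc(N(C)C)c([N+](=O)[O-])c2)cc(OC)c1OC` is recorded only as a limit of > 5000 nM and has no exact number. Compound 4 `COc1cc(/C=C\c2ccc(N(C)C)c([N+](=O)[O-])c2)cc(OC)c1OC` has not yet been measured. The change from compound 3 to compound 4 is the two compounds have the same atoms and bonds and differ only in configuration as drawn: 1 of 1 stereo elements differ; a double bond is drawn E in compound 3 and Z in compound 4 and nothing else: a double bond is drawn E in compound 3 and Z in compound 4. Going by the values given here, no measured pair shows such a change, so the size of the move in this assay is a judgement, but a large move towards stronger inhibition is expected. The expected change is an at least 25-fold lower number from compound 3 to compound 4 (1.39 log units; beyond the scatter) and it carries wide uncertainty. Compound 4 is estimated at 200 nM with an expected range from 20 nM to 3000 nM in the coming measurement.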

Compound 4, half-maximal inhibitory concentration: > 5000 nM
Compound 4 ended at the assay's limit (the forecaster's own chance of this, stated with the estimate: 15%); middle value at least 25-fold (1.39 log units) from the limit.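

No step can be read between compound 3 and compound 4 in this assay, because both rest at the same limit: the limit of > 5000 nM in this assay, at which 2 of the 4 values shown sit. The compounds shown leave open whether the E or Z double bond changes inhibition at all in this assay and, if it does, by how much.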